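Benzyloxycarbonyl on the piperazine nitrogen: the dichlorobenzyl series

The source may hold more compounds than are shown below. What is called first, only, known or untested is meant among the compounds shown, and "the series" means these compounds.

Of the compounds shown here, two sharing a dithiocarbamate-triazole core have been tested in a functional assay on ECa-109 cells (Homo sapiens) for inhibition, read by MTT assay, with a stated time of 72 h; on this read-out higher numbers stand for weaker inhibition and lower numbers for stronger inhibition. Compound 1 `O=C(OCc1ccccc1)N1CCN(C(=S)SCc2cn(Cc3ccc(F)cc3)nn2)CC1`, which carries a benzyloxycarbonyl on the piperazine ring and a fluorine on the benzyl group, gives in this assay a value of 32000 nM. Compound 2 `S=C(SCc1cn(Cc2ccc(Cl)c(Cl)c2)nn1)N1CCNCC1`, with a free ring nitrogen and two chlorines on the benzyl group, is known only by a limit: in this assay compound 2 gives > 128000 nM, which is the limit of the assay and not a number, as noted in the limit of > 128000 nM in this assay, at which 1 of the 2 values shown sits. Compound 2 thus stands at the weak end of what the assay can report.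

Compound 3 `O=C(OCc1ccccc1)N1CCN(C(=S)SCc2cn(Cc3ccc(Cl)c(Cl)c3)nn2)CC1` differs from compound 2 in one place: benzyloxycarbonyl in place of hydrogen on an amine nitrogen in a ring. Compound 1 shows that a compound bearing this group does give a measurable number, at 32000 nM. On that basis the step from compound 2 to compound 3 is expected to go toward stronger inhibition by an at least 3.6-fold lower number from compound 2 to compound 3 (0.56 log units; beyond the scatter), beyond the scatter. Compound 3 is therefore estimated at 35000 nM, within the range 10000 nM to 120000 nM.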

Compound 3, half-maximal inhibitory concentration: 29400 nM
Compound 3: the middle estimate sits 1.2-fold (0.08 log units) above what was measured, and the stated range covers the measured number.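

In this assay, for the compounds shown here, placing benzyloxycarbonyl on the amine nitrogen in the ring, with the 3,4-dichlorophenyl kept in place, gives the first matched reading at this position, and it goes toward stronger inhibition beyond the scatter, with an at least 4.3-fold lower number from compound 2 to compound 3 (0.63 log units; beyond the scatter). As far as these compounds go, compound 2 is known only by a limit of the assay and not by a number, so the true size of this step stays unknown and only its direction and minimum can be read: the limit of > 128000 nM in this assay, at which 1 of the 3 values shown sits. With benzyloxycarbonyl present, exchanging 4-fluorophenyl for 3,4-dichlorophenyl on the saturated chain carbon bound to an aromatic nitrogen gives a 1.1-fold lower number from compound 1 to compound 3 (0.04 log units; within the scatter), so the two compounds that carry this group lie within the scatter of each other, and this exchange on the far side of the core has no readable effect here.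

The compounds shown leave open whether the step needs the whole benzyloxycarbonyl group, since a small acetyl, a plain benzyl without the carbonyl or a methyl on the same nitrogen would separate its parts. They also leave open how other groups on the benzyl ring, such as a methoxy or a nitrile, would read once benzyloxycarbonyl is in place.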